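The source may report more compounds than this note shows. Statements on the series, on what has been measured and on what is new or still open speak of the compounds shown alone.

Compound 1 `Cc1cc(-n2nccn2)cc(C(=O)NNS(=O)(=O)c2ccccc2)c1F` is tested in an ADME assay on microsomes from liver (Mus musculus) for metabolic stability, read by HPLC, using NADPH, with a stated time of 60 min, tested at 1 uM, in the presence of a further agent that is not named here (a lower number here means slower removal, a higher number faster removal of the compound), where compound 1 gives 865 uL/min. Compound 2 `CCOc1cc(C)cc(C(=O)NNS(=O)(=O)c2ccccc2F)c1` reaches only a limit of this assay, > 866 uL/min, so no number is known for it. Compound 3 `O=C(NNS(=O)(=O)c1ccccc1F)c1cccc(-n2cccn2)c1` gives 178 uL/min in this assay, and of the two numbers compound 1 is the higher, with the gap to compound 3 lying beyond the usual scatter (the limit of > 866 uL/min in this assay, at which 1 of the 3 values shown sits). The next compound is compound 4 `Cc1cc(-n2cccn2)cc(C(=O)NNS(=O)(=O)c2ccccc2)c1F`, which differs from compound 1 in a single place: 1H-pyrazol-1-yl in place of 2H-1,2,3-triazol-2-yl on an aromatic carbon. Going by the values given here, with no directly comparable step among the measured compounds, the expected step in this assay from compound 1 to compound 4 is a 1.3-fold lower number from compound 1 to compound 4 (0.12 log units; within the scatter), a small movement downward that stays within the scatter. Compound 4 is therefore estimated at 650 uL/min, with a likely range from 280 uL/min to 1400 uL/min.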

Compound 4, intrinsic clearance in a liver preparation (reported as CLH), per the amount of preparation that the assay uses in the Mus musculus assay: 567 uL/min
The estimate for compound 4 lay 1.1-fold (0.06 log units) above the measured number; the range from low to high includes it.
By their numbers in the Mus musculus assay, from the lowest: compound 3; then compounds 4 and 1 (each within the scatter of the next). At a limit, above all of these: compound 2.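

Going by these compounds alone, this position offers the first single-place comparison. In the Mus musculus assay the exchange of 2H-1,2,3-triazol-2-yl for 1H-pyrazol-1-yl gives a 1.5-fold lower number from compound 1 to compound 4 (0.18 log units; within the scatter) and so leaves the two compounds indistinguishable on this read-out. In a physicochemical assay for solubility, read by nephelometry, measured as kinetic solubility, at pH 2 (on this read-out higher numbers stand for higher solubility and lower numbers for lower solubility), compound 1 gives 25 ug/mL and compound 4 gives 6.3 ug/mL with a 4.0-fold lower number from compound 1 to compound 4 (0.60 log units; beyond the scatter) for the same exchange. On these data alone, what a group of another kind at this aromatic carbon, such as an amine or a carboxylic acid, would do to either read-out stays open.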